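A few compounds are considered here, and "the series" means these few. Any claim that something is new, unique, unknown or untested is made for them only; others in the source may bear on it.

Compound 2, `COc1cc2nccc(Oc3ccc(Nc4nn(C)cc4C(=O)Nc4cccc(F)c4)cc3)c2cc1C(N)=O`, gives 4480 nM in a functional assay on BaF3 cells (Mus musculus) for antiproliferative activity, read by CCK-8 assay and cell counting, with a stated time of 76 h; on this read-out lower numbers stand for stronger inhibition and higher numbers for weaker inhibition. Among the three measured compounds it stands second highest: compound 3, `COc1cc2nccc(Oc3ccc(Nc4nn(C)cc4C(=O)N4CCCCC4)cc3)c2cc1C(N)=O`, gives 5650 nM, and the step of a 1.3-fold higher number from compound 2 to compound 3 (0.10 log units; within the scatter) is within the scatter, while compound 1, `COc1cc2nccc(Oc3ccc(Nc4nn(C)cc4C(=O)Nc4ccccc4F)cc3)c2cc1C(N)=O`, gives 1710 nM, and the step of a 2.6-fold higher number from compound 1 to compound 2 (0.42 log units; beyond the scatter) lies beyond it. That last step is the only measured one in which the fluorine changes place on the ring held by the amide-type nitrogen. The step of a 3.3-fold higher number from compound 1 to compound 3 (0.52 log units; beyond the scatter) shows that exchanging the whole (2-fluorophenyl)amino group for piperidin-1-yl costs about as much as that shift.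

Compound 4, `COc1cc2nccc(Oc3ccc(Nc4nn(C)cc4C(=O)Nc4ccc(F)cc4)cc3)c2cc1C(N)=O`, differs from compound 2 by 4-fluorophenyl in place of 3-fluorophenyl on an amide-type nitrogen. Among the compounds with values here, no measured step covers a 4-fluorophenyl on this nitrogen. Within the data shown here, the nearest precedent, from compound 1 to compound 2, shows that going from 2-fluorophenyl to 3-fluorophenyl weakens inhibition by a modest margin; whether a further change to 4-fluorophenyl continues, reverses or stalls that trend is not decided by the data, and the closeness of compounds 2 and 3 suggests the numbers in this part of the series do not move far. The step of a 1.1-fold lower number from compound 2 to compound 4 (0.05 log units; within the scatter) is therefore expected to be small and without a confident direction. For compound 4 in this assay the estimate is 4000 nM, within a range from 1500 nM to 10000 nM.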

Compound 4, half-maximal inhibitory concentration: 3060 nM
The estimate for compound 4 lay 1.3-fold (0.12 log units) above the measured number, within the range that was stated.
By their numbers in this assay, from the lowest: compounds 1, 4, 2 and 3 (each within the scatter of the next, the first and the last beyond it).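

In this assay the 4-fluorophenyl on the amide-type nitrogen cannot be told apart from either of the other two fluorine placements: the data give a 1.5-fold lower number from compound 2 to compound 4 (0.17 log units; within the scatter) and a 1.8-fold higher number from compound 1 to compound 4 (0.25 log units; within the scatter), even though the scatter is exceeded by a 2.6-fold higher number from compound 1 to compound 2 (0.42 log units; beyond the scatter). The piperidin-1-yl amide is not separated from it either, with a 1.8-fold lower number from compound 3 to compound 4 (0.27 log units; within the scatter), so the fluorophenyl series does not read as an ordered trend across the three placements, and only compound 1 stands apart from compound 2 and from compound 3. Nothing available here bears on the reason for these numbers.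

Still open, from the compounds shown here alone, is whether the fluorine contributes at all, which an unsubstituted phenyl on the same nitrogen would test, as would a chlorophenyl or a methoxyphenyl for the kind of substituent. Also open, going by these compounds, is how far the carbonyl substituent can move from these groups, for instance to a morpholin-4-yl in place of piperidin-1-yl or to a benzylamino group with a longer link to the ring.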